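Working notes: from compound 3 to compound 4

This account rests on a few compounds, and the source may have more. Where it says the series, first, only, none or still open, it means among the compounds named here.

Measured in a functional assay on K562 cells (Homo sapiens) for cytotoxicity, read by sulforhodamine B assay; on this read-out lower numbers stand for higher toxicity in this test and higher numbers for lower toxicity in this test:
- compound 1 `CC1=CC[C@@H]([C@@](C)(O)CCCC(C)(C)NC=S)CC1`: > 100000 nM, a limit
- compound 2 `CC1=CC[C@@H]([C@@](C)(O)CCCC(C)(C)NC(=S)NN)CC1`: 9580 nM
- compound 3 `CC1=CC[C@@H]([C@@](C)(O)CCCC(C)(C)NC(=S)N/N=C\c2ccccc2[N+](=O)[O-])CC1`: > 100000 nM, a limit

Compound 3 stands at > 100000 nM, which is a limit and not a number. For the measured compounds named here, the series so far has (the limit of > 100000 nM in this assay, at which 2 of the 3 values shown sit).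

Compound 4 `CC1=CC[C@@H]([C@@](C)(O)CCCC(C)(C)NC(=S)N/N=C\c2ccc(Cl)cc2)CC1` differs from compound 3 in one place: 4-chlorophenyl in place of 2-nitrophenyl on a carbon with a double bond to nitrogen. This is 4-chlorophenyl in place of 2-nitrophenyl on a carbon with a double bond to nitrogen.

Going by the values given here, no measured step covers this change. The only one, an at least 10-fold lower number from compound 1 to compound 2 (1.01 log units; beyond the scatter), is large and beyond the scatter, but it is a different change, aminoamino in place of hydrogen on a thiocarbonyl carbon. It bears only indirectly, showing that a single change can move a compound of this series a long way in this assay. With compound 3 at a limit, any step that can be read would run toward a lower number. The estimated step is an at least 2.5-fold lower number from compound 3 to compound 4 (0.39 log units; beyond the scatter), and compound 4 may also be expected to stay at the limit. For compound 4 the expected value is 40000 nM, with an estimated range of 10000 nM to 100000 nM.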

Compound 4, concentration lethal to 50% of the cells: 10300 nM
For compound 4 the middle estimate is 3.9-fold (0.59 log units) above the measured one, and the stated range covers the measured number.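

In this assay, the group on the carbon with a double bond to nitrogen decides whether this series gives a measurable number: 4-chlorophenyl in place of 2-nitrophenyl gives an at least 9.7-fold lower number from compound 3 to compound 4 (0.98 log units; beyond the scatter). From the compounds shown here alone, the true size of this step remains unknown because compound 3 sits at a limit and not at a number: the limit of > 100000 nM in this assay, at which 2 of the 4 values shown sit. The group of 9 heavy atoms in place of one nitrogen atom on the amide-type nitrogen gives a 1.1-fold higher number from compound 2 to compound 4 (0.03 log units; within the scatter), which shows that this larger group can be carried there with no difference readable beyond the scatter.

The two aryl groups differ in both substituent and ring position, and the step does not separate these two differences. Going by these compounds, whether chlorine or its placement carries the step remains open, and 2-chlorophenyl, 4-nitrophenyl and unsubstituted phenyl at this place would bear on that question.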